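Quinazolinone ureas: para substituent swap, fluoro to ethoxy

The compounds below may be only part of what the source reports. "The series", "measured", "known", "first", "only" and "open" are said of these compounds alone.

Measured so far:
compound 1 `Cc1nc2ccccc2c(=O)n1NC(=O)Nc1ccc(Br)cc1` — 51%
compound 2 `Cc1nc2ccccc2c(=O)n1NC(=O)Nc1ccc([N+](=O)[O-])cc1` — 40%
compound 3 `Cc1nc2ccccc2c(=O)n1NC(=O)Nc1ccc(F)cc1` — 45%

All three share one core and differ only in the group on the aromatic carbon of the terminal phenyl ring. In a functional assay on the whole organism for inhibition, with Mus musculus as the target, with a stated time of 1 h, at a dose of 100 mg/kg by the intraperitoneal route (on this read-out higher numbers stand for more inhibition at the one dose given (going by the name of the read-out) and lower numbers for less inhibition), compound 1 gives 51%, compound 2 gives 40%, and compound 3 gives 45%. Compound 3 stands second of the three numbers, but its gaps to both neighbours are within the scatter: a number 6 percentage points lower from compound 1 to compound 3 (within the scatter) and a number 5 percentage points higher from compound 2 to compound 3 (within the scatter). Only a number 11 percentage points lower from compound 1 to compound 2 (beyond the scatter) reaches beyond the scatter, and even that step is modest.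

Compound 4 `CCOc1ccc(NC(=O)Nn2c(C)nc3ccccc3c2=O)cc1` is not yet measured. The change from compound 3 is ethoxy in place of fluoro on an aromatic carbon. Going by the values given here, no measured step involves ethoxy. Among the compounds with values here, the steps that bear on it are the para-substituent swaps already seen: fluoro in place of bromo and fluoro in place of nitro, both within the scatter, and nitro in place of bromo, modest. The whole series therefore moves within a narrow band whatever sits on that carbon, so for this assay the expected step of no change at the digits printed from compound 3 to compound 4 (within the scatter) is none beyond the scatter. Compound 4 is estimated at 45%, with a range from 30% to 60%.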

Compound 4, a percentage reported as inhibition, in the whole organism at one dose (the size of the read-out at that dose, not a potency): 45%
The estimate for compound 4 equals the measured number at the digits printed, within the range that was stated.
By their numbers in this assay, from the lowest: compounds 2, 3, 4 and 1 (each within the scatter of the next, the first and the last beyond it).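

Within this assay, ethoxy on this aromatic carbon, para to a large group, brings the first carbon chain and oxygen link to the position, with 3 heavy atoms entering where fluoro had 1, and the step reads no change at the digits printed from compound 3 to compound 4 (within the scatter). The same change set against the other two groups gives a number 5 percentage points higher from compound 2 to compound 4 (within the scatter) and a number 6 percentage points lower from compound 1 to compound 4 (within the scatter), so compound 4 sits within the scatter of every earlier compound and the read-out at this position does not separate ethoxy from bromo, nitro or fluoro. Going by these compounds alone, the series now holds four different groups at this carbon, and the only step beyond the scatter is still the one between the bromo and nitro compounds, while no data here explain why the read-out stays so level at this position.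

Still open, on these data alone, is whether a longer chain such as butoxy, or a group of another kind such as an amine or a carboxylic acid, would move the number clearly out of this band. As far as these compounds go, the numbers also come from a single dose, so whether compound 3 and compound 4 would stay level at other doses remains unknown.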